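Swapping the aryl group on a fused bicyclic core

A few compounds are considered here, and "the series" means these few. Any claim that something is new, unique, unknown or untested is made for them only; others in the source may bear on it.

Measured compounds:
- compound 1 `COc1ccc(-c2cn3ccnc3c(-c3ccc4ncn(C5CCCCC5)c4c3)n2)cc1`, 69.6%
- compound 2 `c1ccc2c(-c3cn4ccnc4c(-c4ccc5ncn(C6CCCCC6)c5c4)n3)cccc2c1`, 7.43%
- compound 3 `c1cn2cc(-c3ccsc3)nc(-c3ccc4ncn(C5CCCCC5)c4c3)c2n1`, 4.9%

In a functional assay on LOX IMVI cells (Homo sapiens) for inhibition, read by sulforhodamine B assay, with a stated time of 48 h, tested at 10 uM (a higher number here means more inhibition at the concentration tested (going by the name of the read-out), a lower number less inhibition), compound 3 gives 4.9%, the lowest of the three numbers; compound 2 sits within the scatter of it, while compound 1 stands far above it. The unmeasured compound 4 `Clc1ccc(-c2cn3ccnc3c(-c3ccc4ncn(C5CCCCC5)c4c3)n2)cc1` differs from compound 3 in one place: 4-chlorophenyl in place of thiophen-3-yl on an aromatic carbon. Within the data shown here, two measured steps bear on this change. The step of a number 64.7 percentage points lower from compound 1 to compound 3 (beyond the scatter) shows that replacing 4-methoxyphenyl with thiophen-3-yl removes most of the inhibition, and the step of a number 62.2 percentage points lower from compound 1 to compound 2 (beyond the scatter) shows a similar loss with naphthalen-1-yl, whereas the step of a number 2.5 percentage points lower from compound 2 to compound 3 (within the scatter) is within the scatter. Among the measured compounds shown here, compound 4 returns to a six-membered carbon-only ring, as in compound 1, though with chlorine rather than methoxy, and no measured step covers that particular exchange. A sizeable rise is therefore expected, a number 40.1 percentage points higher from compound 3 to compound 4 (beyond the scatter), but with wide uncertainty. Compound 4 is estimated at 45%, within a range from 10% to 80%.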

Compound 4, a percentage reported as inhibition, at one concentration (the size of the read-out at that concentration, not a potency): 14.8%
For compound 4 the middle estimate is 30.2 percentage points above the measured one; measured number inside the range.
By their numbers in this assay, from the lowest: compounds 3, 2 and 4 (each within the scatter of the next); then compound 1.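

In this assay, a six-membered carbon-only ring at this position is not enough for inhibition: 4-chlorophenyl stays within the scatter of both other groups that lost it, with a number 9.9 percentage points higher from compound 3 to compound 4 (within the scatter) and a number 7.4 percentage points higher from compound 2 to compound 4 (within the scatter). Among the four compounds, only the 4-methoxyphenyl group stands apart, and the single exchange of chloro for methoxy on the same ring gives a number 54.8 percentage points lower from compound 1 to compound 4 (beyond the scatter), so the inhibition depends on that substituent and not on the ring alone. No measurement is available that explains this difference between chloro and methoxy.

What the compounds shown leave open is whether other substituents in place of methoxy on this ring, such as ethoxy, hydroxy or dimethylamino, would keep the inhibition. They also leave open whether a methoxy group on naphthalen-1-yl or thiophen-3-yl would restore it.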